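Pyrrolyl in place of methylpiperazinyl on compound 3

The source may report more compounds than this note shows. Statements on the series, on what has been measured and on what is new or still open speak of the compounds shown alone.

Compound 3 `COc1cc(OC)c2c(=O)cc(C(=O)Nc3ccc(N4CCN(C)CC4)cc3)[nH]c2c1` has been tested in an ADME assay on BJ cells (Homo sapiens) for antiproliferative activity, with a stated time of 72 h; a higher number here means that more compound is needed for the effect, a lower number that less compound is needed. In this assay compound 3 gives > 19800 nM, which is a limit of the assay and not a number. Going by the values given here, compound 1 `COc1ccc(-c2c(Cl)c(=O)c3c(OC)cc(OC)cc3n2S(=O)(=O)c2ccc(OC)cc2)cc1`, built on a different core, gives 90000 nM in this assay, the only plain number among the three. Compound 2 `COc1ccc(-c2cc(=O)c3c(OC)cc(OC)cc3n2S(=O)(=O)c2ccc(C=O)cc2)cc1` gives > 34400 nM, again a limit rather than a number. Compound 3 therefore stands at the lower of the two limits, the limit of > 19800 nM in this assay, at which 1 of the 3 values shown sits, being its own and the limit of > 34400 nM in this assay, at which 1 of the 3 values shown sits, belonging to compound 2, and no step between any two of these compounds has been worked out.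

Compound 4 `COc1cc(OC)c2c(=O)cc(C(=O)Nc3ccc(-n4cccc4)cc3)[nH]c2c1` differs from compound 3 in a single place: 1H-pyrrol-1-yl in place of 4-methylpiperazin-1-yl on an aromatic carbon. Among the compounds with values here, with no measured step to draw on, the expectation rests on compound 3 sitting at > 19800 nM and on compound 1 sitting at 90000 nM. The estimated step is a step that the limit leaves unreadable from compound 3 to compound 4, which amounts to no movement beyond the scatter. Compound 4 is accordingly estimated at 40000 nM, with a range from 10000 nM to 150000 nM, and it is likely that this assay will again report only a limit.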

Compound 4, half-maximal effective concentration: > 77000 nM
Compound 4: only a limit was reported; the forecaster's own chance of this, stated with the estimate: 60%; middle value at least 1.9-fold (0.28 log units) from the limit.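

In this assay compound 3 gives > 19800 nM, a limit of the assay and not a number. Going by these compounds alone, compound 4 gives > 77000 nM, also a limit, and no step between compound 3 and compound 4 can be read. The compounds shown leave open whether 1H-pyrrol-1-yl in place of 4-methylpiperazin-1-yl changes the concentration needed in this assay at all.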